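Alpha-substituent variation on the acid chain

This account rests on a few compounds, and the source may have more. Where it says the series, first, only, none or still open, it means among the compounds named here.

Measured so far:
- compound 1 `CCOC(=O)CCCC/C=C(\c1ccccc1)c1cccnc1` — 600 nM
- compound 2 `O=C(O)C(CCC/C=C(\c1ccccc1)c1cccnc1)C1(O)CCCC1` — 65 nM
- compound 3 `COCC(CCC/C=C(\c1ccccc1)c1cccnc1)C(=O)O` — 41 nM

In an assay (Equus caballus) for inhibition of Thromboxane-A synthase (Homo sapiens), using microsomes (a higher number here means a weaker inhibitor, a lower number a stronger inhibitor), compound 3 gives the lowest number of the three: the gap to compound 2 lies within the scatter, while the step of a 15-fold lower number from compound 1 to compound 3 (1.17 log units; beyond the scatter) lies beyond it. Compound 4 `CC(C)CSC(CCC/C=C(\c1ccccc1)c1cccnc1)C(=O)O` is not yet measured; it differs from compound 3 by isobutylsulfanyl in place of methoxymethyl on a saturated chain carbon bound to a carbonyl carbon and a saturated chain carbon. Going by the values given here, the one measured step at this position, a 1.6-fold lower number from compound 2 to compound 3 (0.20 log units; within the scatter), fell within the scatter, so substituent exchange there has not yet moved this assay clearly. A step within the scatter is therefore expected, a 1.2-fold higher number from compound 3 to compound 4 (0.09 log units; within the scatter). Compound 4 is estimated at 50 nM, with a range from 20 nM to 150 nM.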

Compound 4, half-maximal inhibitory concentration: 110 nM
Compound 4: middle estimate off by 2.2-fold (0.34 log units), on the low side; the measured number falls inside the stated range.
By their numbers in this assay, from the lowest: compounds 3, 2 and 4 (each within the scatter of the next, the first and the last beyond it); then compound 1.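

Substituent exchange at this saturated chain carbon now moves the number in this assay beyond the scatter, with a 2.7-fold higher number from compound 3 to compound 4 (0.43 log units; beyond the scatter). Isobutylsulfanyl still stays within the scatter of 1-hydroxycyclopentyl, with a 1.7-fold higher number from compound 2 to compound 4 (0.23 log units; within the scatter), so the separation appears against methoxymethyl only. Nothing available explains this difference.

Open, from the compounds shown here alone, is whether methylsulfanyl, with a shorter chain on sulfur, would read with methoxymethyl or with isobutylsulfanyl. Also open, going by these compounds, is how an amine on this carbon would compare with these three groups.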